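A few compounds are considered here, and "the series" means these few. Any claim that something is new, unique, unknown or untested is made for them only; others in the source may bear on it.

Of the compounds shown here, two have been measured in an assay on isolated protein for agonist activity at Free fatty acid receptor 1 (Homo sapiens); a higher number here means that more compound is needed for the effect, a lower number that less compound is needed. Compound 1 `CC#CC(CC(=O)O)c1ccc(OCc2ccn3cc(-c4ccc(C5CCCCC5)cc4)nc3c2)cc1` gives 559 nM, and compound 2 `CC#CC(CC(=O)O)c1ccc(OCc2ccc3nc(-c4ccccc4C)cn3c2)cc1` gives 389 nM. Compound 2 has the lower of the two numbers, but compound 1 sits only a little above it, and that gap lies within the usual scatter of this assay, so the two cannot be told apart on these numbers alone. Compound 3 `CC#CC(CC(=O)O)c1ccc(OCc2ccc3nc(-c4ccc(C)cc4)cn3c2)cc1` has not yet been measured. It is built from the same atoms as compound 2, joined differently: 4-methylphenyl in place of 2-methylphenyl on an aromatic carbon. Among the measured compounds shown here, no measured pair in this set shows how this exchange is reflected in this assay, so nothing here points to a step in either direction beyond the scatter. Compound 2 gives 389 nM, and with no step beyond the scatter expected, compound 3 is estimated at 350 nM with a range of 120 nM to 1000 nM. The step that this estimate means is a 1.1-fold lower number from compound 2 to compound 3 (0.05 log units; within the scatter), expected to stay within the scatter.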

Compound 3, half-maximal effective concentration: 507 nM
The estimate for compound 3 lay 1.4-fold (0.16 log units) below the measured number; the range from low to high includes it.
By their numbers in this assay, from the lowest: compounds 2, 3 and 1 (each within the scatter of the next).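

In this assay, among the compounds shown here, the pair gives the first direct reading of a change on this aromatic carbon of the five-membered aromatic ring: 4-methylphenyl in place of 2-methylphenyl gives a 1.3-fold higher number from compound 2 to compound 3 (0.12 log units; within the scatter). On this pair, the two methylphenyl groups cannot be told apart, so the exchange shows no measurable effect on the number in this assay. Nothing available here bears on this result.

As far as these compounds go, it remains open whether the flat result extends to other groups at this carbon, such as an unsubstituted phenyl, a chlorophenyl or a methoxyphenyl, or whether any of them would give a step beyond the scatter. Compound 1 differs from compound 2 and compound 3 in more than one place, so it cannot show what its cyclohexyl group contributes.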